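The source may hold more compounds than are shown below. What is called first, only, known or untested is meant among the compounds shown, and "the series" means these compounds.

Working notes on the series.

Two compounds sharing one core have numbers in an assay on isolated protein for inhibition of Apoptosis regulator Bcl-2 (Homo sapiens), read by fluorescence polarization, with a stated time of 60 min (a higher number here means a weaker inhibitor, a lower number a stronger inhibitor), so far. Compound 1, `CCCCc1c(-c2ccc(C(=O)NS(=O)(=O)c3ccc4ccccc4c3)cc2C(=O)N2CCc3ccccc3C2)c(C(=O)OCC)nn1-c1cccc(Oc2ccccc2)c1`, carries an ethyl ester and a 3-phenoxyphenyl on the core; in this assay compound 1 gives 140 nM. Compound 2, `CCCCc1c(-c2ccc(C(=O)NS(=O)(=O)c3ccc4ccccc4c3)cc2C(=O)N2CCc3ccccc3C2)c(CO)nn1-c1ccc(-c2ccccc2)cc1`, carries a hydroxymethyl and a 4-phenylphenyl instead; in this assay compound 2 gives 7 nM, the lowest of the two numbers, with compound 1 standing at a higher number, beyond the scatter. The two compounds differ in two places at once, so no single step can be read from the pair.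

Compound 3, `CCCCc1c(-c2ccc(C(=O)NS(=O)(=O)c3ccc4ccccc4c3)cc2C(=O)N2CCc3ccccc3C2)c(CO)nn1-c1cccc(CO)c1`, keeps the hydroxymethyl of compound 2 and changes only the group on the aromatic nitrogen: 3-(hydroxymethyl)phenyl in place of 4-phenylphenyl on an aromatic nitrogen. The group that enters is smaller, with one ring where there were two, and brings one hydrogen-bond donor and one acceptor.

Among the measured compounds shown here, no measured step isolates this exchange. Given that compound 2 holds the lowest number with 7 nM, the expected step is a 4.3-fold higher number from compound 2 to compound 3 (0.63 log units; beyond the scatter), towards a higher number and likely beyond the scatter. Compound 3 is estimated at 30 nM, within 8 nM to 120 nM.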

Compound 3, half-maximal inhibitory concentration: 71 nM
Estimate against measurement, compound 3: 2.4-fold (0.37 log units) below; the measured number falls inside the stated range.
By their numbers in this assay, from the lowest: compound 2; then compounds 3 and 1 (each within the scatter of the next).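

In this assay, among the compounds shown here, with the hydroxymethyl on the core held constant, placing 3-(hydroxymethyl)phenyl in place of 4-phenylphenyl on the aromatic nitrogen gives a 10-fold higher number from compound 2 to compound 3 (1.01 log units; beyond the scatter), the first step that isolates a single place. The group on this nitrogen therefore moves the number well beyond the scatter on its own, and the direction favours the two-ring 4-phenylphenyl of compound 2 over the one-ring group of compound 3. This single exchange bundles several differences, namely the loss of a ring, fewer heavy atoms, a new hydrogen-bond donor and acceptor, and a different point of attachment on the ring, and no measurement available here accounts for the size of the step.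

An unsubstituted phenyl or a 4-(hydroxymethyl)phenyl on the same nitrogen would help to separate the contribution of the second ring from that of the hydroxymethyl and its attachment point. The exchange of ethyl ester for hydroxymethyl on the core also stays unresolved, since compound 1 differs from compound 2 and from compound 3 in two places, and a carboxylic acid or a primary amide at that place would extend the comparison.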